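The source may hold more compounds than are shown below. What is called first, only, known or untested is meant among the compounds shown, and "the series" means these compounds.

Among the measured compounds shown here, compound 2 `FC(F)(F)c1ccc(CSc2nc(Nc3ccc(C(F)(F)F)cc3)c3ccccc3n2)cc1` gives 6170 nM in a functional assay on MGC-803 cells (Homo sapiens) for cytotoxicity, read by MTT assay, with a stated time of 72 h (a higher number here means a weaker inhibitor, a lower number a stronger inhibitor), and it is the only compound of the pair with a number rather than a limit in this assay. Compound 1 `CCOc1ccccc1Nc1nc(SCc2ccc(C(F)(F)F)cc2)nc2ccccc12`, which carries 2-ethoxyphenyl on the same nitrogen, sits at the limit of the assay with > 50000 nM. For the measured compounds named here, the single measured step, an at least 8.1-fold lower number from compound 1 to compound 2 (0.90 log units; beyond the scatter), is bounded on one side by the limit of > 50000 nM in this assay, at which 1 of the 2 values shown sits, so its true size is not known, only that it is at least modest.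

Compound 3 `Cc1ccc(Nc2nc(SCc3ccc(C(F)(F)F)cc3)nc3ccccc23)cc1` differs from compound 2 by methyl in place of trifluoromethyl on an aromatic carbon, placed on an aromatic carbon of a six-membered aromatic ring of carbon only, para to a large group. Going by the values given here, no measured step alters only this substituent; the step from compound 1 to compound 2 exchanges the whole aryl group and yields only a bound. The direction of the change in this assay cannot be read from the data, and a step of modest size in either direction, or none beyond the scatter, remains possible. The expected step is a 1.9-fold higher number from compound 2 to compound 3 (0.29 log units; within the scatter), leaning toward a weaker inhibitor. Compound 3 is accordingly estimated at 12000 nM, with a range from 3000 nM to 50000 nM.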

Compound 3, half-maximal inhibitory concentration: 36100 nM
Compound 3: the middle estimate sits 3.0-fold (0.48 log units) below what was measured; the range from low to high includes it.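

In this assay, the exchange of trifluoromethyl for methyl on an aromatic carbon of a six-membered aromatic ring of carbon only, para to a large group, now has a measured size of its own: a 5.9-fold higher number from compound 2 to compound 3 (0.77 log units; beyond the scatter). This separates the substituent from the whole-aryl exchange of the earlier step and shows that this single change moves the number beyond the scatter, toward a weaker inhibitor. With 4-methylphenyl in place of 2-ethoxyphenyl, the step is an at least 1.3-fold lower number from compound 1 to compound 3 (0.14 log units; that floor lies within the scatter), and it stays a floor that does not by itself set compound 3 apart from compound 1, so its true size is unknown: the limit of > 50000 nM in this assay, at which 1 of the 3 values shown sits.

The compounds shown place only trifluoromethyl and methyl at this position, so it remains open how a chlorine atom, a methoxy group or a nitrile would rank there. Also open, from the compounds shown here alone, is what an amine or a carboxylic acid would do in place of the other trifluoromethyl group, which all three compounds share.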